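Swapping a Chlorophenyl for an Indolyl on the Shared Core

The compounds below may be only part of what the source reports. "The series", "measured", "known", "first", "only" and "open" are said of these compounds alone.

Compound 1, `COc1ccc(-c2cc3nccc(-c4cc(OC)c(OC)c(OC)c4)n3n2)cc1N`, gives 88 nM in a functional assay on B16-F0 cells (Mus musculus) for inhibition, read by CCK-8 assay, with a stated time of 48 h; on this read-out higher numbers stand for weaker inhibition and lower numbers for stronger inhibition.
Compound 2, `COc1cc(-c2ccnc3cc(-c4ccc(C)cc4)nn23)cc(OC)c1OC`, gives 21 nM in this assay.
Compound 3, `COc1cc(-c2ccnc3cc(-c4ccc(Cl)cc4)nn23)cc(OC)c1OC`, gives 4090 nM in this assay.

Compound 3 stands at the highest number of the three, which on this read-out means the weakest inhibition. Both steps into it are large and go beyond the scatter: a 46-fold higher number from compound 1 to compound 3 (1.67 log units; beyond the scatter) and a 190-fold higher number from compound 2 to compound 3 (2.29 log units; beyond the scatter). Compound 4, `COc1cc(-c2ccnc3cc(-c4ccc5cc[nH]c5c4)nn23)cc(OC)c1OC`, keeps the same core and differs from compound 3 in one place: 1H-indol-6-yl in place of 4-chlorophenyl on an aromatic carbon. For the measured compounds named here, no measured step brings in an indolyl, so the expectation rests on what the two steps into compound 3 show: both exchanges of the group on that aromatic carbon moved the number by a large amount, and the one in the lower direction, a 190-fold higher number from compound 2 to compound 3 (2.29 log units; beyond the scatter), was the larger. The change to compound 4 is therefore expected to lower the number strongly, roughly a 41-fold lower number from compound 3 to compound 4 (1.61 log units; beyond the scatter). For compound 4 the estimated value in this assay is 100 nM, with a range from 20 nM to 600 nM.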

Compound 4, half-maximal inhibitory concentration: 55 nM
Compound 4: the middle estimate sits 1.8-fold (0.26 log units) above what was measured, within the range that was stated.
By their numbers in this assay, from the lowest: compound 2; then compounds 4 and 1 (each within the scatter of the next); then compound 3.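

In this assay the high number of compound 3 turns out not to hold for larger groups at this position, since the 1H-indol-6-yl, a five-membered ring fused to the six-membered one and carrying a hydrogen-bond donor, gives a 74-fold lower number from compound 3 to compound 4 (1.87 log units; beyond the scatter) in one exchange. Among the better groups it does not match 4-methylphenyl, with a 2.6-fold higher number from compound 2 to compound 4 (0.42 log units; beyond the scatter) as the gap, and it cannot be told apart from 3-amino-4-methoxyphenyl, with a 1.6-fold lower number from compound 1 to compound 4 (0.20 log units; within the scatter) as the difference. Three quite different groups on this carbon thus all give far lower numbers than 4-chlorophenyl, and nothing available explains why.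

The compounds shown leave open how 4-fluorophenyl or 4-bromophenyl would read, and so whether the high number of compound 3 extends to other halogens. They also leave open whether the indole needs its ring hydrogen, which a methyl group on that nitrogen would test.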